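Removing a Trifluoromethyl Group: Expected Tolerance in Cells

The source may hold more compounds than are shown below. What is called first, only, known or untested is meant among the compounds shown, and "the series" means these compounds.

Compound 1 `COc1ccccc1NC(=O)COc1cc(C)nc2ccc(C(F)(F)F)cc12` is one of three related compounds tested in an ADME assay on HepG2 cells (Homo sapiens) for cytotoxicity, read by trypan blue exclusion, with a stated time of 48 h, in the presence of a further agent that is not named here; a higher number here means that more compound is tolerated, a lower number that less compound is tolerated. In this assay compound 1 reaches only a limit, > 128000 nM. Compound 2 `COc1ccc2nc(C)cc(OCC(=O)Nc3ccc(C)cc3)c2c1` likewise reaches only a limit, > 149000 nM. Compound 3 `COCCNC(=O)COc1cc(C)nc2ccc(OC)cc12` also reaches only a limit, > 164000 nM. The one change among these compounds, a step that the two limits leave unreadable from compound 2 to compound 3, cannot be read, since both ends of it are limits. Compound 4 `COc1ccccc1NC(=O)COc1cc(C)nc2ccccc12` is not yet measured; it differs from compound 1 by hydrogen in place of trifluoromethyl on an aromatic carbon. Within the data shown here, no measured step touches this change, and every value shown is a limit, so no step in this assay beyond the usual scatter can be foreseen in either direction. Compound 4 is therefore expected to give 150000 nM, within 100000 nM to 250000 nM. That amounts to an expected step that the limit leaves unreadable from compound 1 to compound 4.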

Compound 4, half-maximal cytotoxic concentration: 43900 nM
For compound 4 the middle estimate is 3.4-fold (0.53 log units) above the measured one; measured number outside the range, below it.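

Among these compounds, compound 4 is the first compound here to give a measured number rather than a limit, so this aromatic carbon is the first place where a change can be seen to matter in this assay. Hydrogen in place of trifluoromethyl gives an at least 2.9-fold lower number from compound 1 to compound 4 (0.46 log units; beyond the scatter), meaning that less compound is tolerated without the group. The full size of this step cannot be read, because compound 1 sits at a limit: the limit of > 128000 nM in this assay, at which 1 of the 4 values shown sits.

The compounds shown leave open whether a smaller group at this carbon, such as a single fluorine or an amine, would restore tolerance. They also leave open whether the same change would have a similar effect with a different group on the amide nitrogen.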